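A few compounds are considered here, and "the series" means these few. Any claim that something is new, unique, unknown or untested is made for them only; others in the source may bear on it.

Of the compounds shown here, three sharing one core have been tested in a functional assay on the whole organism (strain NMRI) with Mus musculus as the target, with a stated time of 60 min, at a dose of 5 mg/kg by the intraperitoneal route; on this read-out higher numbers stand for a stronger effect at the one dose given and lower numbers for a weaker effect. Compound 1 `S=c1[nH]nc(Cc2ccc(Cl)cc2Oc2ccccc2Cl)[nH]1` gives 124% in that test. Compound 2 `CCSc1nnc(Cc2ccc(Cl)cc2Oc2ccccc2Cl)[nH]1` gives 134%, and compound 3 `Clc1ccc(Cc2nnc(SCc3ccccc3)[nH]2)c(Oc2ccccc2Cl)c1` gives 113%. Compound 2 has the highest of the three numbers: the step of a number 10 percentage points higher from compound 1 to compound 2 (within the scatter) is within the scatter, so compound 1 and compound 2 cannot be told apart, while the step of a number 21 percentage points lower from compound 2 to compound 3 (beyond the scatter) is beyond it.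

Compound 4 `CCSc1nnc(Cc2ccc(Cl)cc2Oc2ccccc2F)[nH]1` has not yet been measured. It differs from compound 2 in one place: fluoro in place of chloro on an aromatic carbon. Neither measured step bears on this change. The step from compound 1 to compound 2 and the step from compound 2 to compound 3 both alter the group attached to the saturated chain carbon or to the sulfur, and the 2-chlorophenoxy group stays the same in all three measured compounds. An exchange of chloro for fluoro on that ring is therefore untested in this series, and no evidence points in either direction.

With nothing to indicate a shift, the expected step is a number 9 percentage points lower from compound 2 to compound 4 (within the scatter), which would keep compound 4 within the scatter of compound 2. Compound 4 is accordingly estimated to give 125% in this assay, with an expected range from 100% to 150%.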

Compound 4, a percentage reported as activity, at one dose (the size of the read-out at that dose, not a potency): 126%
Compound 4: the middle estimate sits 1 percentage points below what was measured; measured number inside the range.
By their numbers in this assay, from the lowest: compound 3; then compounds 1, 4 and 2 (each within the scatter of the next).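

In this assay, within the data shown here, fluoro in place of chloro on the phenoxy ring gives a number 8 percentage points lower from compound 2 to compound 4 (within the scatter), and this is the first reading of any change on that ring, since the 2-chlorophenoxy group stays the same in compounds 1, 2 and 3. On this reading, the 2-chlorophenoxy and 2-fluorophenoxy groups cannot be told apart at this place, ortho to a large group, so the exchange of one halogen for the other leaves no effect that can be distinguished from the usual spread of repeated measurements. Nothing at hand speaks to why the two compounds read alike.

The compounds shown leave open how a different kind of group at this place, such as methoxy, trifluoromethyl or an amine, would read, as a single halogen exchange says little about the position beyond this one pair. They also leave open whether fluoro and chloro would still read alike with a longer chain on the sulfur, and, with only one dose given, whether the two would also match at other doses.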